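Fluorine pattern on the benzyl group and cytotoxicity

This account rests on a few compounds, and the source may have more. Where it says the series, first, only, none or still open, it means among the compounds named here.

Measured so far:
compound 1 `COc1cccc2c1c(C(=O)/C=C(\O)C(=O)O)cn2Cc1ccc(F)c(F)c1`: 71000 nM
compound 2 `COc1cccc2c1c(C(=O)/C=C(\O)C(=O)O)cn2Cc1cccc(F)c1F`: 17500 nM

In an ADME assay on MT4 cells (Homo sapiens) for cytotoxicity, read by MTT assay (on this read-out lower numbers stand for higher toxicity in this test and higher numbers for lower toxicity in this test), compound 2 stands at the lower of the two numbers. Among the compounds with values here, the single measured step is a 4.1-fold lower number from compound 1 to compound 2 (0.61 log units; beyond the scatter). Compound 3 `COc1cccc2c1c(C(=O)/C=C(\O)C(=O)O)cn2Cc1ccccc1F` differs from compound 2 by hydrogen in place of fluoro on an aromatic carbon. Within the data shown here, the only step that bears on this is a 4.1-fold lower number from compound 1 to compound 2 (0.61 log units; beyond the scatter), which also rearranged fluoro on the same benzyl group; its size suggests that the fluorine pattern shifts this assay by a modest amount, with no clear direction. A modest step of a 1.7-fold higher number from compound 2 to compound 3 (0.23 log units; within the scatter) is therefore expected. Compound 3 is estimated at 30000 nM, range 10000 nM to 90000 nM.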

Compound 3, half-maximal cytotoxic concentration: 70500 nM
Beside the measured number, compound 3's estimate is 2.4-fold (0.37 log units) below it, and the stated range covers the measured number.
By their numbers in this assay, from the lowest: compound 2; then compounds 3 and 1 (each within the scatter of the next).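

In this assay, hydrogen in place of fluoro on the 2,3-difluorophenyl group gives (a 4.0-fold higher number from compound 2 to compound 3 (0.61 log units; beyond the scatter)), so the lower number goes with the 2,3-difluorophenyl pattern, not with fluoro on the benzyl group as such. The 2-fluorobenzyl and 3,4-difluorophenyl patterns stand level (a 1.0-fold lower number from compound 1 to compound 3 (0.00 log units; within the scatter)), so the count of fluoro groups alone does not track the numbers across these three compounds. No measurement at hand explains this pattern. Open, on these data alone, is whether chloro or trifluoromethyl on that aromatic carbon would give a number like that of the 2,3-difluorophenyl pattern.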